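Naphthyloxyacetohydrazones: cytotoxicity on HEL cells, methoxy for chloro

This account rests on a few compounds, and the source may have more. Where it says the series, first, only, none or still open, it means among the compounds named here.

Three hydrazones built on the shared core carry different aryl groups on the carbon doubly bonded to nitrogen. Compound 1 `C/C(=N\NC(=O)COc1cccc2ccccc12)c1ccc(C#N)cc1Br` gives 20 ug/mL in an ADME assay on HEL cells (Homo sapiens) for cytotoxicity; on this read-out lower numbers stand for higher toxicity in this test and higher numbers for lower toxicity in this test. For the measured compounds named here, compound 3 `C/C(=N\NC(=O)COc1cccc2ccccc12)c1ccc(O)cc1` gives 20 ug/mL in this assay, and the only single-point step on record, no change at the digits printed from compound 1 to compound 3 (within the scatter), lies within the scatter. Compound 2 `O=C(COc1cccc2ccccc12)N/N=C/c1ccc(Cl)cc1` gives 100 ug/mL in this assay, the highest of the three numbers and beyond the scatter from both compound 1 and compound 3.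

Compound 4 `COc1ccc(/C=N/NC(=O)COc2cccc3ccccc23)cc1` is not yet measured. It differs from compound 2 as follows: methoxy in place of chloro on an aromatic carbon. Going by the values given here, no measured step shows this same exchange; the one step on record swaps the whole aryl group on a carbon that also bears a methyl, and it is flat. Nothing here therefore points to a direction beyond the scatter, and the hydrazone aldehyde-derived compound 2 is the closest anchor.

Compound 4 is expected to stay near compound 2, with a step of about a 1.4-fold lower number from compound 2 to compound 4 (0.15 log units; within the scatter) in this assay. The estimate for compound 4 is 70 ug/mL, expected between 20 ug/mL and 200 ug/mL.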

Compound 4, minimum cytotoxic concentration: 20 ug/mL
Compound 4: the middle estimate sits 3.5-fold (0.54 log units) above what was measured; low and high end bracket the measured number.
By their numbers in this assay, from the lowest: compounds 1, 3 and 4 (each within the scatter of the next); then compound 2.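

In this assay the record now holds a 5.0-fold lower number from compound 2 to compound 4 (0.70 log units; beyond the scatter) for a single substituent exchange, so this one exchange is enough to move the read-out beyond the scatter. The flat result in no change at the digits printed from compound 1 to compound 3 (within the scatter) therefore does not carry over to this place: that step swapped the whole aryl group on a carbon that also bears a methyl, whereas here a small exchange on an otherwise unchanged 4-chlorophenyl framework gives a visible, though modest, step. Nothing on record explains why this exchange has such an effect on the read-out.

The compounds shown leave open whether the step reflects something particular to chloro or to methoxy, which would need other groups at the same place, such as an amine, a carboxylic acid or a longer ether chain like ethoxy. They also leave open what the methyl on the carbon doubly bonded to nitrogen contributes, as no pair shown differs in that methyl alone.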